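Fluoro in place of nitro on an aromatic carbon

The source may report more compounds than this note shows. Statements on the series, on what has been measured and on what is new or still open speak of the compounds shown alone.

In a functional assay on HeLa cells (Homo sapiens) for inhibition, read by MTT assay, with a stated time of 72 h (a lower number here means a stronger inhibitor, a higher number a weaker inhibitor), compound 1 (`O=[N+]([O-])c1ccc(-c2nnc(SCCCN3CCN(c4nc5ccccc5o4)CC3)o2)cc1`) gives 114000 nM and compound 2 (`Fc1ccc(-c2nnc(SCCCN3CCN(c4nc5ccccc5o4)CC3)o2)cc1`) gives 196000 nM while compound 3 (`O=[N+]([O-])c1ccc(-c2nnc(SCCCN3CCN(c4nc5ccccc5s4)CC3)o2)cc1`) gives 97800 nM on the same read-out. Compound 3 lies within the scatter of both other compounds, so these numbers set no order among the three.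

Compound 4 (`Fc1ccc(-c2nnc(SCCCN3CCN(c4nc5ccccc5s4)CC3)o2)cc1`) departs from compound 3 by one exchange: fluoro in place of nitro on an aromatic carbon so that 4-nitrophenyl becomes 4-fluorophenyl.

The same exchange has been measured once, in the step of a 1.7-fold higher number from compound 1 to compound 2 (0.24 log units; within the scatter) and that step stays within the scatter. Within the data shown here, the only other measured step of a 1.2-fold lower number from compound 1 to compound 3 (0.07 log units; within the scatter) links the two groups on the ring amine nitrogen and also stays within the scatter. A step of similar size and direction in this assay is therefore expected, though one measured pair is thin support. The estimated step is a 1.6-fold higher number from compound 3 to compound 4 (0.21 log units; within the scatter) and it is expected to remain within the scatter. Compound 4 is estimated at 160000 nM with an expected range of 90000 nM to 290000 nM for this number.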

Compound 4, half-maximal inhibitory concentration: 134000 nM
Beside the measured number, compound 4's estimate is 1.2-fold (0.08 log units) above it; measured number inside the range.
By their numbers in this assay, from the lowest: compounds 3, 1, 4 and 2 (each within the scatter of the next).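

In this assay, fluoro in place of nitro on an aromatic carbon now has a second reading, on the core of compound 3 (a 1.4-fold higher number from compound 3 to compound 4 (0.14 log units; within the scatter)), and the two readings agree within the scatter: the same change on two cores in this assay, a 1.7-fold higher number (0.24 log units; within the scatter) from compound 1 to compound 2 and a 1.4-fold higher number (0.14 log units; within the scatter) from compound 3 to compound 4, 1.3-fold (0.10 log units) apart, within the scatter of two such steps.
The exchange on the ring amine nitrogen, 1,3-benzothiazol-2-yl in place of 1,3-benzoxazol-2-yl, also gains a second reading (a 1.5-fold lower number from compound 2 to compound 4 (0.17 log units; within the scatter)), again in agreement with the first: the same change on two cores in this assay, a 1.2-fold lower number (0.07 log units; within the scatter) from compound 1 to compound 3 and a 1.5-fold lower number (0.17 log units; within the scatter) from compound 2 to compound 4, 1.3-fold (0.10 log units) apart, within the scatter of two such steps.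
Each exchange has now been read on both partners, and no step among these four compounds leaves the scatter, so neither place separates them in this assay.

The compounds shown leave open whether an amine or a carboxylic acid in place of fluoro, on the same aromatic carbon, would give a step beyond the scatter. As far as these compounds go, whether any other group on the ring amine nitrogen would do so also remains open.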